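Nitro for formyl on an alkyne-linked phenylpropanoic acid

This account rests on a few compounds, and the source may have more. Where it says the series, first, only, none or still open, it means among the compounds named here.

The two measured compounds share a core in which a phenylpropanoic acid is joined through an alkyne to a second aromatic ring. Compound 1 `O=Cc1cccc(C#Cc2ccc(CCC(=O)O)cc2)c1` carries a formyl group on that second ring and, in an in vitro functional assay on 1321-N1 cells for agonist activity at Free fatty acid receptor 1 (Homo sapiens), read by fluorescence (on this read-out higher numbers stand for an effect only at larger amounts of compound and lower numbers for an effect already at smaller amounts), compound 1 gives 355 nM. Compound 2 `Cc1ccc(C#Cc2ccc(CCC(=O)O)cc2)cc1` carries a methyl group instead and in this assay compound 2 gives 107 nM. On these two numbers compound 1 stands highest; its nearest neighbour, compound 2, shows a lower number, and the gap between them lies beyond the usual scatter.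

Compound 3 `O=C(O)CCc1ccc(C#Cc2cccc([N+](=O)[O-])c2)cc1` is the next member. It differs from compound 1 in a single place: nitro in place of formyl on an aromatic carbon. Among the measured compounds shown here, no measured pair shows this exact exchange, so the expectation for compound 3 rests on the values of compound 1 and compound 2 alone. Since both substituents sit on the same aromatic carbon, the step from compound 1 to compound 3 is expected to be small, a 1.4-fold lower number from compound 1 to compound 3 (0.15 log units; within the scatter), most likely within the scatter or a modest move toward lower numbers. Compound 3 is therefore estimated at 250 nM in this assay, with a likely range from 80 nM to 800 nM.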

Compound 3, half-maximal effective concentration: 58.9 nM
For compound 3 the middle estimate is 4.2-fold (0.63 log units) above the measured one; the measured number lies below the stated range.
By their numbers in this assay, from the lowest: compounds 3 and 2 (each within the scatter of the next); then compound 1.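

Nitro in place of formyl on this aromatic carbon, meta to a large group, brings a 6.0-fold lower number from compound 1 to compound 3 (0.78 log units; beyond the scatter) in this assay and so is far from a silent exchange. Among the compounds shown here, the earlier compounds held no pair differing at this place alone, so this is the first reading of what a change here does by itself, and it shows that the number responds to which group sits on this carbon, even though both groups have 1 double bond outside aromatic rings, 0 hydrogen-bond donors and no net charge. The count shifts only from 2 heavy atoms and 1 hydrogen-bond acceptor in formyl to 3 heavy atoms and 2 hydrogen-bond acceptors in nitro, and no available measurement of any property of these groups explains the size of the step.

On these data alone, whether the lower number belongs to nitro in particular, or would also come with a nitrile, an amine or a carboxylic acid on the same carbon, remains open. With a single pair standing for this exchange, the compounds shown also leave open whether nitro would give a like step on another carbon of that ring.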